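The source may hold more compounds than are shown below. What is called first, only, known or untested is meant among the compounds shown, and "the series" means these compounds.

Compounds in this set share one core and differ only in the group attached to an aromatic carbon of the five-membered ring. Compound 2 `CS(=O)(=O)Nc1ccc(-n2cc(-c3ccccc3)nn2)cc1Oc1ccccc1` carries a phenyl there, and in a functional assay on HepG2 cells (Homo sapiens) for inhibition, read by MTT assay, with a stated time of 48 h (a higher number here means a weaker inhibitor, a lower number a stronger inhibitor), compound 2 gives 13600 nM. Compound 3 `CS(=O)(=O)Nc1ccc(-n2cc(COc3ccccc3Cl)nn2)cc1Oc1ccccc1` carries a (2-chlorophenoxy)methyl instead; in this assay compound 3 gives 25300 nM. Compound 1 `CS(=O)(=O)Nc1ccc(-n2cc(COc3ccc([N+](=O)[O-])cc3)nn2)cc1Oc1ccccc1`, with a (4-nitrophenoxy)methyl at the same place, has no reported result: in this assay compound 1 gives "not determined" (no result reported). Compound 2 and compound 3 therefore stand at about the same level: the step of a 1.9-fold higher number from compound 2 to compound 3 (0.27 log units; within the scatter) is the only one available, and it does not rise above the scatter.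

Compound 4 `CS(=O)(=O)Nc1ccc(-n2cc(COc3ccc(Cl)cc3)nn2)cc1Oc1ccccc1` is the next variation, described by (4-chlorophenoxy)methyl in place of phenyl on an aromatic carbon. Within the data shown here, the one comparable step, from compound 2 to compound 3, involved a closely related chlorinated group and stayed within the scatter, so no shift beyond the scatter is expected here either, at most a small drift toward a higher number. Compound 4 is estimated at 20000 nM, within a range of 8000 nM to 50000 nM, which means an expected step of a 1.5-fold higher number from compound 2 to compound 4 (0.17 log units; within the scatter).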

Compound 4, half-maximal inhibitory concentration: 7500 nM
Compound 4: the middle estimate sits 2.7-fold (0.43 log units) above what was measured, and the stated range ends above it.
By their numbers in this assay, from the lowest: compounds 4, 2 and 3 (each within the scatter of the next, the first and the last beyond it).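

Among these compounds, the first step beyond the scatter at this aromatic carbon comes from a change within the side group, not from replacing the whole group: (4-chlorophenoxy)methyl in place of (2-chlorophenoxy)methyl gives a 3.4-fold lower number from compound 3 to compound 4 (0.53 log units; beyond the scatter) in this assay. So where the chlorine sits on the phenoxy ring can shift the result, although the change is modest. Replacing phenyl with (4-chlorophenoxy)methyl gives a 1.8-fold lower number from compound 2 to compound 4 (0.26 log units; within the scatter), so these two different groups remain at about the same level, and nothing available here explains the difference between the two chlorinated compounds.

On these data alone, it remains open whether this effect is specific to chlorine or would also appear with fluorine or a methoxy group on the same ring. Also open, as far as these compounds go, is how an amine or a carboxylic acid at this aromatic carbon would compare.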